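A few compounds are considered here, and "the series" means these few. Any claim that something is new, unique, unknown or untested is made for them only; others in the source may bear on it.

Measured compounds:
compound 1 `O=C1NC2(CC2c2ccc3cccc(OCc4ccccc4)c3n2)C(=O)N1c1ccc(Br)cc1`: 300 mg/kg
compound 2 `CCC(CO)N1C(=O)NC2(CC2c2ccc3cccc(OCc4ccccc4)c3n2)C1=O`: 30 mg/kg

In a functional assay on the whole organism (strain Kunming) with Mus musculus as the target, in the maximal electroshock model, with a stated time of 4 h (on this read-out higher numbers stand for an effect only at larger amounts of compound and lower numbers for an effect already at smaller amounts), compound 2 gives 30 mg/kg, the lowest of the two numbers, while compound 1 gives 300 mg/kg. Among the measured compounds shown here, the only measured step, a 10-fold lower number from compound 1 to compound 2 (1.00 log units; beyond the scatter), bears on the change to compound 3 `O=C1NC2(CC2c2ccc3cccc(OCc4ccccc4)c3n2)C(=O)N1Cc1ccccc1`, which carries benzyl in place of 1-(hydroxymethyl)propyl on an amide-type nitrogen in a ring. Benzyl is neither the 4-bromophenyl of compound 1 nor the 1-(hydroxymethyl)propyl of compound 2, so a number between those two values is expected. Compound 3 is estimated at 100 mg/kg (range 30 mg/kg to 300 mg/kg). For compound 3 this means an expected step of a 3.3-fold higher number from compound 2 to compound 3 (0.52 log units; beyond the scatter).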

Compound 3, minimum effective dose: 300 mg/kg
Compound 3: middle estimate off by 3.0-fold (0.48 log units), on the low side; the range from low to high includes it.
By their numbers in this assay, from the lowest: compound 2; then compounds 1 and 3 (each within the scatter of the next).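

In this assay, benzyl in place of 1-(hydroxymethyl)propyl on the amide-type ring nitrogen gives a 10-fold higher number from compound 2 to compound 3 (1.00 log units; beyond the scatter), whereas benzyl in place of 4-bromophenyl gives no change at the digits printed from compound 1 to compound 3 (within the scatter). Among these three compounds, the two with an aromatic ring on this nitrogen sit level, and only the open-chain, hydroxyl-bearing 1-(hydroxymethyl)propyl of compound 2 stands apart. Nothing available explains this difference.

Whether the hydroxyl or the carbon chain of that group accounts for the gap remains open. A sec-butyl, 2-hydroxyethyl or 2-aminoethyl group on the same nitrogen would help separate the two.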